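A few compounds are considered here, and "the series" means these few. Any claim that something is new, unique, unknown or untested is made for them only; others in the source may bear on it.

Working notes on the series. Compound 3 `CCCCCCCCCCCCCCNC(=O)[C@@H](NC(=O)c1ccco1)[C@@H](C)O` is the point of departure. In a functional assay on MCF7 cells (Homo sapiens) for cytotoxicity, read by MTT assay, with a stated time of 48 h (a higher number here means a weaker inhibitor, a lower number a stronger inhibitor), compound 3 gives 105000 nM, the highest of the three numbers recorded. The nearest is compound 2 `CCCCCCCCNC(=O)[C@@H](NC(=O)c1ccco1)[C@@H](C)O`, which in this assay gives 91800 nM; the gap is a 1.1-fold higher number from compound 2 to compound 3 (0.06 log units; within the scatter), so the two values sit together within the scatter. Further off is compound 1 `CCCCCCCCCCCCCCNC(=O)[C@@H](N)[C@@H](C)O`, carrying the free amine, which in this assay gives 10700 nM; the step of a 9.8-fold higher number from compound 1 to compound 3 (0.99 log units; beyond the scatter) is beyond the scatter.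

Compound 4 `CCCCCCCCCCCCCCNC(=O)[C@@H](NC(=O)c1nccc2ccccc12)[C@@H](C)O` differs from compound 3 at one position: isoquinolin-1-yl in place of furan-2-yl on a carbonyl carbon. Neither measured step speaks to an exchange of one aromatic acyl group for another. The step of a 9.8-fold higher number from compound 1 to compound 3 (0.99 log units; beyond the scatter) concerns the presence of the acyl group, not its identity, and the step of a 1.1-fold higher number from compound 2 to compound 3 (0.06 log units; within the scatter) concerns the length of the chain. The data therefore give no basis for a direction, and the expectation for this assay is a step that need not exceed the scatter, with a wide range either way. Compound 4 is thus estimated at 70000 nM in this assay, within 15000 nM to 250000 nM. The expected step is a 1.5-fold lower number from compound 3 to compound 4 (0.18 log units; within the scatter).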

Compound 4, half-maximal inhibitory concentration: 22800 nM
Estimate against measurement, compound 4: 3.1-fold (0.49 log units) above, and the stated range covers the measured number.
By their numbers in this assay, from the lowest: compound 1; then compound 4; then compounds 2 and 3 (each within the scatter of the next).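

In this assay, among these compounds, the exchange of furan-2-yl for isoquinolin-1-yl on a carbonyl carbon gives a 4.6-fold lower number from compound 3 to compound 4 (0.66 log units; beyond the scatter), so the identity of the aromatic acyl group counts at this position, a point the earlier steps could not address. The rise seen on acylation, a 9.8-fold higher number from compound 1 to compound 3 (0.99 log units; beyond the scatter), therefore describes the furan-2-yl amide and cannot be read as applying to every acyl group: with isoquinolin-1-yl in its place, compound 4 gives 22800 nM, though this printed value still stands above that of compound 1 at 10700 nM. Nothing available on the series explains the step from furan-2-yl to isoquinolin-1-yl.

Among the compounds shown here, the single exchange changes the ring system and the hetero atom together, so it remains open whether the ring nitrogen or the larger aromatic system carries the step, a question that a naphthalen-1-yl or a plain phenyl group on the same carbonyl carbon would help to separate. On these data alone, it also remains open whether the isoquinolin-1-yl amide would keep its value on the shorter chain of compound 2, or whether a longer chain would shift it.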